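Working notes: from compound 3 to compound 4

A few compounds are considered here, and "the series" means these few. Any claim that something is new, unique, unknown or untested is made for them only; others in the source may bear on it.

Measured so far in a functional assay on the whole organism (stomach) with Rattus norvegicus as the target; on this read-out lower numbers stand for an effect already at smaller amounts and higher numbers for an effect only at larger amounts of compound
- compound 1 `CCCCCCCC/N=C/N1CCC(C(c2ccccc2)c2ccccc2)CC1` gives 1.1 mg/kg
- compound 2 `OCCCCCCCC/N=C/N1CCC(C(c2ccccc2)c2ccccc2)CC1` gives 9.7 mg/kg
- compound 3 `OCCCCCC/N=C/N1CCC(C(c2ccccc2)c2ccccc2)CC1` gives 4.5 mg/kg

Compound 3 holds the middle of the three numbers, closer to compound 2 than to compound 1. Next is compound 4 `COC(=O)CCCCCCC/N=C/N1CCC(C(c2ccccc2)c2ccccc2)CC1`, reached by this change ((methoxycarbonyl)methyl in place of hydroxy on a saturated chain carbon, six bonds along the chain from a double-bonded nitrogen). The bearing steps are modest: an 8.8-fold higher number from compound 1 to compound 2 (0.95 log units; beyond the scatter) and a 4.1-fold higher number from compound 1 to compound 3 (0.61 log units; beyond the scatter), with a 2.2-fold lower number from compound 2 to compound 3 (0.33 log units; beyond the scatter) between the two hydroxy compounds. None of them introduces (methoxycarbonyl)methyl, so they only suggest the likely size. From the compounds shown here alone, no step beyond the scatter is therefore expected in this assay, and the direction stays open. The expected step is a 1.2-fold higher number from compound 3 to compound 4 (0.09 log units; within the scatter) on this estimate. Compound 4 is estimated at 5.5 mg/kg (expected range 1.8 mg/kg to 16 mg/kg).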

Compound 4, dose for half-maximal effect: 4.7 mg/kg
For compound 4 the middle estimate is 1.2-fold (0.07 log units) above the measured one; the measured number falls inside the stated range.
By their numbers in this assay, from the lowest: compound 1; then compounds 3 and 4 (each within the scatter of the next); then compound 2.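

In this assay, placing (methoxycarbonyl)methyl on this saturated chain carbon in place of hydroxy gives a 1.0-fold higher number from compound 3 to compound 4 (0.02 log units; within the scatter), so a chain with 0 hydrogen-bond donors in the entering group can match the hydroxy compound 3. The ester also stays apart from the unsubstituted chain, with a 4.3-fold higher number from compound 1 to compound 4 (0.63 log units; beyond the scatter), and from the longer hydroxy chain, with a 2.1-fold lower number from compound 2 to compound 4 (0.31 log units; beyond the scatter). Nothing available accounts for these steps.

From the compounds shown here alone, whether a carboxylic acid or an amine in place of methoxycarbonyl would fall with compound 3 and compound 4 stays open. So does the effect of a longer chain carrying the ester.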